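A Chloro Group on the Leading Compound

This account rests on a few compounds, and the source may have more. Where it says the series, first, only, none or still open, it means among the compounds named here.

In a functional assay on MCF7 cells (Homo sapiens) for inhibition, read by sulforhodamine B assay, with a stated time of 48 h, tested at 10 uM (on this read-out higher numbers stand for more inhibition of growth at the one concentration tested and lower numbers for less inhibition of growth), compound 1 `CC(=O)c1ccc(NC(=O)Cn2nc(-c3ccc(Cl)cc3)nc2N)cc1` gives 5.48%, compound 3 `COc1cc(-c2nc3sc(-c4ccccc4)cn3n2)cc(OC)c1OC` gives 23%, and compound 2 `COc1ccc(-c2nc3sc(-c4ccccc4)cn3n2)cc1` gives 74%. Compound 2 therefore stands highest of the three, and its gaps to both others lie beyond the usual scatter of repeated measurements.

Compound 4 `COc1ccc(-c2nc3sc(-c4ccc(Cl)cc4)cn3n2)cc1` differs from compound 2 in one place: chloro in place of hydrogen on an aromatic carbon. Chloro takes the place of hydrogen on an aromatic carbon, so a phenyl becomes a 4-chlorophenyl. Among the measured compounds shown here, no measured pair shows this change on its own, so the data offer no direct guide to it. The core of compound 2 is also present in compound 3, which gives 23%, so a shared core alone does not secure a high number. A single-atom change is expected to cause a small downward move, probably within the scatter, although the uncertainty is wide. The estimated step is a number 9 percentage points lower from compound 2 to compound 4 (within the scatter). For compound 4, the estimated value is 65%, with an expected range of 35% to 90%.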

Compound 4, percent growth inhibition at one concentration: 51.1%
Compound 4: middle estimate off by 13.9 percentage points, on the high side, within the range that was stated.
By their numbers in this assay, from the lowest: compound 1; then compound 3; then compound 4; then compound 2.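

Among the compounds shown here, putting a chloro group on the phenyl, so that it becomes a 4-chlorophenyl, gives the first comparison where only one place changes, and in this assay it brings a number 22.9 percentage points lower from compound 2 to compound 4 (beyond the scatter) on this modest evidence. This aromatic carbon is therefore not indifferent to what it carries: a single heavy atom moves the number by more than repeat measurements would scatter, although compound 4 still gives 51.1% in this one test. Nothing available explains why the number falls with this change.

For the compounds shown here, with only one step at this carbon, it remains open whether a smaller fluoro group, an amine or a carboxylic acid there would give a higher or lower number. Going by these compounds, it is also open whether chloro would have a similar effect on the same phenyl of compound 3, which shares the core.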